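Working notes: aryl exchange on the ring amine nitrogen

A few compounds are considered here, and "the series" means these few. Any claim that something is new, unique, unknown or untested is made for them only; others in the source may bear on it.

In a functional assay on HL-60 cells (Homo sapiens) for inhibition, read by MTT assay, with a stated time of 72 h (a lower number here means a stronger inhibitor, a higher number a weaker inhibitor), three compounds sharing one core have been measured. Compound 1 `Cc1nc(-c2ccccc2)c(C(=O)N2CCN(c3ccccc3C(F)(F)F)CC2)o1` gives 120 nM, compound 2 `Cc1nc(-c2ccccc2)c(C(=O)N2CCN(c3c(C)cccc3C)CC2)o1` gives 146 nM, and compound 3 `Cc1nc(-c2ccccc2)c(C(=O)N2CCN(c3ccc(Cl)c(Cl)c3)CC2)o1` gives 124 nM. Compound 3 therefore stands level with the other two. The steps that reach it are a 1.0-fold higher number from compound 1 to compound 3 (0.01 log units; within the scatter) and a 1.2-fold lower number from compound 2 to compound 3 (0.07 log units; within the scatter), and the remaining step is a 1.2-fold higher number from compound 1 to compound 2 (0.09 log units; within the scatter). All three lie within the scatter.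

Compound 4 `Cc1nc(-c2ccccc2)c(C(=O)N2CCN(c3ccccc3F)CC2)o1` is not yet measured. It carries 2-fluorophenyl in place of 3,4-dichlorophenyl on an amine nitrogen in a ring. The three measured steps bear on this change, as each exchanges one substituted phenyl group for another at the same place. Among the compounds with values here, no measured compound carries 2-fluorophenyl, and three compounds make a narrow basis. The nearest measured group by name is the 2-(trifluoromethyl)phenyl of compound 1, at 120 nM.

No step beyond the scatter is expected in either direction, and the expected step is a 1.1-fold higher number from compound 3 to compound 4 (0.04 log units; within the scatter). For compound 4 the estimated value is 135 nM, with an expected range of 70 nM to 270 nM.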

Compound 4, half-maximal inhibitory concentration: 147 nM
Compound 4: middle estimate off by 1.1-fold (0.04 log units), on the low side; low and high end bracket the measured number.
By their numbers in this assay, from the lowest: compounds 1, 3, 2 and 4 (each within the scatter of the next).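

The new compound adds a fourth aryl group on the amine nitrogen in a ring: in this assay, 2-fluorophenyl in place of 3,4-dichlorophenyl gives a 1.2-fold higher number from compound 3 to compound 4 (0.07 log units; within the scatter), and 2-fluorophenyl in place of 2,6-dimethylphenyl gives a 1.0-fold higher number from compound 2 to compound 4 (0.00 log units; within the scatter). Fluoro in place of trifluoromethyl on an aromatic carbon gives a 1.2-fold higher number from compound 1 to compound 4 (0.09 log units; within the scatter), the first step in the series that exchanges one substituent and leaves the rest of the aryl group unchanged, and it too stays within the scatter, so all four compounds now read level at this position. No measurement shown here bears on why these aryl groups read alike.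

As far as these compounds go, all four groups at this nitrogen are substituted phenyl groups, so it remains open whether the level reading holds for a benzyl group, or for a phenyl group carrying a carboxylic acid or a dimethylamino group. The methyl and phenyl groups on the shared core are the same in all four compounds, which leaves the response to any change at those places open.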